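Replacing chloro with bromo on the shared core

The compounds below may be only part of what the source reports. "The series", "measured", "known", "first", "only" and "open" are said of these compounds alone.

compound 1 `CNC1=NS(=O)(=O)c2cc(F)ccc2N1`: > 300 uM
compound 2 `CNC1=NS(=O)(=O)c2cc(Cl)ccc2N1`: 142 uM
compound 3 `CCCNC1=NS(=O)(=O)c2cc(Cl)ccc2N1`: 55.5 uM

All three compounds were tested in a functional assay (aorta) with Rattus norvegicus as the target; on this read-out lower numbers stand for an effect already at smaller amounts and higher numbers for an effect only at larger amounts of compound. For compound 1, the entry > 300 uM is a limit of the assay and not a number. For the measured compounds named here, only two true numbers therefore remain for comparison. Compound 2, with 142 uM, has the higher of them, and its nearest neighbour is compound 3, with 55.5 uM.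

Compound 4 `CNC1=NS(=O)(=O)c2cc(Br)ccc2N1` differs from compound 2 in one place, with bromo in place of chloro on an aromatic carbon. The most relevant measured change also swaps one group for another on that aromatic carbon: chloro in place of fluoro gave an at least 2.1-fold lower number from compound 1 to compound 2 (0.32 log units; beyond the scatter). That size rests on (the limit of > 300 uM in this assay, at which 1 of the 3 values shown sits), so it is a bound and not an exact step. The other change, ethyl in place of hydrogen on the chain, gave a 2.6-fold lower number from compound 2 to compound 3 (0.41 log units; beyond the scatter), but it lies elsewhere in the molecule and offers little guidance here.

A single bounded step is thin support, so only a small further drop in the number is expected, one that stays within the scatter. The expected change is a 1.5-fold lower number from compound 2 to compound 4 (0.17 log units; within the scatter). The estimate for compound 4 is 95 uM, with an expected range from 40 uM to 220 uM.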

Compound 4, concentration for half-maximal effect: 31 uM
For compound 4 the middle estimate is 3.1-fold (0.49 log units) above the measured one; measured number outside the range, below it.
By their numbers in this assay, from the lowest: compounds 4 and 3 (each within the scatter of the next); then compound 2. At a limit, above all of these: compound 1.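

In this assay, for the compounds shown here, the exchange on this aromatic carbon matters more than the earlier compounds could show: a 4.6-fold lower number from compound 2 to compound 4 (0.66 log units; beyond the scatter), although only one heavy atom changes and no ring, charge, hydrogen-bond donor or hydrogen-bond acceptor enters or leaves. Among the three groups seen at this position, fluoro, chloro and bromo, the number falls with each exchange, and the whole span from the first group to the last amounts to an at least 9.6-fold lower number from compound 1 to compound 4 (0.98 log units; beyond the scatter). That span gives only a minimum, and the size of the first exchange cannot be set against the second, since the entry for compound 1 is a limit of the assay and not a number: the limit of > 300 uM in this assay, at which 1 of the 4 values shown sits.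

The compounds shown leave open whether the fall continues with iodo, or whether a group of a different kind on the same carbon, such as a nitrile or a methoxy group, would fit the same trend. They also leave open whether bromo and the longer chain of compound 3, when joined in one molecule, would lower the number further than either change does alone.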